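Bromo in place of acetyl on the para-substituted phenyl

This account rests on a few compounds, and the source may have more. Where it says the series, first, only, none or still open, it means among the compounds named here.

Compound 3 `CC(=O)c1ccc(-c2cn3ccnc3c(-c3ccc4ncn(C5CCCCC5)c4c3)n2)cc1` sits lowest of the three measured numbers: in a functional assay on MDA-MB-468 cells (Homo sapiens) for inhibition, read by sulforhodamine B assay, with a stated time of 48 h, tested at 10 uM (on this read-out higher numbers stand for more inhibition at the one concentration tested (going by the name of the read-out) and lower numbers for less inhibition), compound 3 gives 0.73%. Compound 1 `c1ccc(-c2cn3ccnc3c(-c3ccc4ncn(C5CCCCC5)c4c3)n2)cc1`, carrying hydrogen on that carbon, gives 54.4%, and compound 2 `Fc1ccc(-c2cn3ccnc3c(-c3ccc4ncn(C5CCCCC5)c4c3)n2)cc1`, carrying fluoro there, gives 19.5%. The steps into compound 3 were both downward and beyond the scatter: a number 53.7 percentage points lower from compound 1 to compound 3 (beyond the scatter), and a number 18.8 percentage points lower from compound 2 to compound 3 (beyond the scatter), while a number 34.9 percentage points lower from compound 1 to compound 2 (beyond the scatter).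

Compound 4 `Brc1ccc(-c2cn3ccnc3c(-c3ccc4ncn(C5CCCCC5)c4c3)n2)cc1` differs from compound 3 by bromo in place of acetyl on an aromatic carbon. For the measured compounds named here, no measured step shows bromo directly; what bears on the change is the acetyl-entering steps, which were large and downward, so the departure of acetyl is expected to recover much of that loss, and the closest measured neighbour, compound 2 with a single halogen atom on the same carbon, gives 19.5%. Compound 4 is therefore expected to rise, with a number 21.3 percentage points higher from compound 3 to compound 4 (beyond the scatter). The estimate for compound 4 is 22%, within 2% to 48%.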

Compound 4, a percentage reported as inhibition, at one concentration (the size of the read-out at that concentration, not a potency): 33.7%
Beside the measured number, compound 4's estimate is 11.7 percentage points below it, and the stated range covers the measured number.
By their numbers in this assay, from the lowest: compound 3; then compound 2; then compound 4; then compound 1.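

With bromo on this carbon, most of the loss seen with acetyl is recovered (a number 33 percentage points higher from compound 3 to compound 4 (beyond the scatter)), so in this assay the drop depends on which group enters, not merely on the carbon carrying a substituent. The two halogens also give different numbers (a number 14.2 percentage points higher from compound 2 to compound 4 (beyond the scatter)), so a single halogen atom here does not settle the outcome. Bromo still does not return the number to that of the unsubstituted phenyl (a number 20.7 percentage points lower from compound 1 to compound 4 (beyond the scatter)), and among the compounds shown, fluoro, bromo and acetyl all sit lower than hydrogen.

Nothing measured here accounts for the order of these groups. As far as these compounds go, it remains open whether an amine, a methoxy group or a carboxylic acid on this carbon would sit nearer compound 1 or compound 3, and whether the same order would hold on another carbon of this ring.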